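Three aziridine rings on one quinone core

The source may hold more compounds than are shown below. What is called first, only, known or untested is meant among the compounds shown, and "the series" means these compounds.

Compound 1 `CC1=C(N2CC2)C(=O)C(CC(C)OC(N)=O)=C(N2CC2)C1=O` carries two aziridin-1-yl groups on its quinone core together with a longer carbamate-bearing side chain. Within the data shown here, in a functional assay on L1210 cells (Mus musculus), with a stated time of 1 days (a lower number here means a less potent compound, a higher number a more potent compound, by a factor of ten per unit of this negative logarithm), compound 1 gives 5.18, the higher of the two numbers measured so far. Compound 2 `CCC1=C(N2CC2)C(=O)C(C(COC(N)=O)OC)=C(N2CC2)C1=O`, which differs in several places, gives 4.92 in this assay, and the two values lie within the scatter of each other, so nothing can be said about an order between them.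

Compound 3 `CC1=C(N2CC2)C(=O)C(N2CC2)=C(N2CC2)C1=O` has not been measured. It differs from compound 1 in a single place: a group of 3 heavy atoms (2 carbon, 1 nitrogen; one three-membered non-aromatic ring with 1 hetero atom) in place of a group of 7 heavy atoms (4 carbon, 1 nitrogen, 2 oxygen; no ring), on a double-bonded ring carbon. The result is a core that bears three aziridin-1-yl groups rather than two, with the methyl group retained.

Among the measured compounds shown here, no step between two measured compounds that differ in only one place is available, so the size of the change can only be guessed from the structures. Exchanging the open chain for a third aziridin-1-yl group is expected to raise the value by a number 0.82 log units higher from compound 1 to compound 3 (beyond the scatter) in this assay. Compound 3 is therefore estimated at 6, with a plausible range from 5 to 7.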

Compound 3, logarithm of the reciprocal of the active concentration, log(1/C): 5.69
The estimate for compound 3 lay 0.31 log units above the measured number, within the range that was stated.
By their numbers in this assay, from the lowest: compounds 2 and 1 (each within the scatter of the next); then compound 3.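

Among these compounds, replacing the open chain on this double-bonded ring carbon with an aziridin-1-yl group gives, in this assay, a number 0.51 log units higher from compound 1 to compound 3 (beyond the scatter), and this is the first change that can be tied to a single place. The earlier pair differed in several places and its numbers lay within the scatter of each other, so it could show neither a direction nor a position. This step shows that the number at this position responds to what is attached there, and that the carbamate-bearing chain of compound 1 is not required for activity in this assay, since compound 3 lacks it and still gives the higher number. Among the compounds shown here, nothing measured so far explains why the number rises.

With only one replacement at this position, the compounds cannot separate the gain from adding a third aziridin-1-yl group from the gain of removing the open chain. A simple amine, a methoxy group or a shorter chain ending in a carbamate on the same ring carbon would help tell these two readings apart, as each keeps part of one group or the other.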